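Dimethylamino Gives Way to Fluoro, Without a Starting Number

The source may report more compounds than this note shows. Statements on the series, on what has been measured and on what is new or still open speak of the compounds shown alone.

Among the compounds with values here, only compound 1 `O=C1CS/C(=N\c2nc3cc(-c4ccc(Cl)cc4)sc3s2)N1` has a number so far: in a functional assay on MDA-MB-231 cells (Homo sapiens) for inhibition, read by MTT assay, with a stated time of 72 h (a lower number here means a stronger inhibitor, a higher number a weaker inhibitor), compound 1 gives 18800 nM, which marks it as a weak inhibitor. Compound 2 `CN(C)c1ccc(/C=C2/S/C(=N\c3nc4cc(-c5ccc(Cl)cc5)sc4s3)NC2=O)cc1` offers no number to start from, since the entry for compound 2 in this assay reads "not determined" (no result reported). The next compound is compound 3 `O=C1N/C(=N/c2nc3cc(-c4ccc(Cl)cc4)sc3s2)S/C1=C/c1ccc(F)cc1`. The structural change is fluoro in place of dimethylamino on an aromatic carbon, para to a large group, so 4-(dimethylamino)phenyl becomes 4-fluorophenyl. Within the data shown here, no measured step shows what such a swap does here, so its size cannot be read from the data. Among the measured compounds shown here, the only guide is compound 1 at 18800 nM, and in this assay a result close to that, perhaps slightly stronger and not clearly beyond the scatter, is expected. Compound 3 is estimated at 10000 nM, with an expected range from 2500 nM to 40000 nM.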

Compound 3, half-maximal inhibitory concentration: 24700 nM
The estimate for compound 3 lay 2.5-fold (0.39 log units) below the measured number, within the range that was stated.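

Within the data shown here, compound 2 has no number to set beside compound 3, so no step between them can be read. From the compounds shown here alone, what fluoro in place of dimethylamino does in this assay stays open. Nothing shown here offers an explanation for the result of compound 3.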